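The source may hold more compounds than are shown below. What is called first, only, known or untested is meant among the compounds shown, and "the series" means these compounds.

In a functional assay on SK-MEL-28 cells (Homo sapiens) for cytotoxicity, read by MTT assay, with a stated time of 72 h (on this read-out lower numbers stand for stronger inhibition and higher numbers for weaker inhibition), compound 1 `O=C(c1ccccc1)c1sc(N2CCCC2)nc1Cl` gives 98000 nM. Compound 2 `O=C(c1ccccc1)c1sc(N2CCCCC2)nc1Cl` carries the change piperidin-1-yl in place of pyrrolidin-1-yl on an aromatic carbon relative to compound 1, and in this assay compound 2 gives 91000 nM. That change made a 1.1-fold lower number from compound 1 to compound 2 (0.03 log units; within the scatter), so the two compounds cannot be told apart on this read-out.

Compound 3 `COC(=O)c1sc2nc(N3CCCC3)sc2c1C` is built on a different core; the difference between the two cores is not broken down here. In this assay compound 3 gives only a limit of > 100000 nM, which means no number was reached for it.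

Compound 4 `COC(=O)c1sc2nc(N3CCCCC3)sc2c1C` has not been measured yet. It differs from compound 3 by piperidin-1-yl in place of pyrrolidin-1-yl on an aromatic carbon. Within the data shown here, this is the same kind of change as the one from compound 1 to compound 2, but its surroundings are not identical: in compound 1 the ring carrying the group is two ring bonds from the ring atom that bears a chloro group and two ring bonds from the ring atom that bears a group of 8 heavy atoms, whereas in compound 3 the ring is part of a fused or bridged system of two rings.

The earlier step was a 1.1-fold lower number from compound 1 to compound 2 (0.03 log units; within the scatter). For compound 4 the expected step is a step that the limit leaves unreadable from compound 3 to compound 4, because compound 3 already sits at the limit of > 100000 nM in this assay, at which 1 of the 3 values shown sits, and the same kind of change left compound 1 and compound 2 within the scatter of each other. Compound 4 is therefore estimated to give 150000 nM in this assay, most likely again only a limit, with an expected range from 60000 nM to 400000 nM.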

Compound 4, half-maximal inhibitory concentration: > 100000 nM
Compound 4 was reported as a limit (the forecaster's own chance of this, stated with the estimate: 70%); the middle value is on the limit's open side.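

Among these compounds, compound 3 and compound 4 are both reported only as limits, so no step between them can be read and the change to piperidin-1-yl in place of pyrrolidin-1-yl has no readable size on this core: the limit of > 100000 nM in this assay, at which 2 of the 4 values shown sit.

The compounds shown leave open how far either compound lies past that limit, and whether this change does anything on this core, where compound 1 and compound 2 offer no direct answer.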